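The source may report more compounds than this note shows. Statements on the series, on what has been measured and on what is new or still open speak of the compounds shown alone.

In an ADME assay on a cell-free system (plasma, Homo sapiens) for protein binding (on this read-out lower numbers stand for a smaller free fraction and higher numbers for a larger free fraction), compound 2 `Cc1c(CF)nnc2sc(C(=O)NC3CN(c4ncc(C(F)(F)F)cn4)C3)c(N)c12` gives 0.042, the lowest of the two numbers shown, and compound 1 `Cc1nnc2sc(C(=O)NC3CN(c4ncc(C(F)(F)F)cn4)C3)c(N)c2c1C` gives 0.048, a gap that lies within the usual scatter. Compound 3 `COc1cc(N2CC(NC(=O)c3sc4nnc(Cl)c(C)c4c3N)C2)c(Cl)cn1` gives only a limit of this assay, < 0.001. Compound 4 `Cc1c(Cl)nnc2sc(C(=O)NC3CN(c4ncc(C(F)(F)F)cn4)C3)c(N)c12` differs from compound 2 by chloro in place of fluoromethyl on an aromatic carbon. For the measured compounds named here, the one measured step, a 1.1-fold lower number from compound 1 to compound 2 (0.06 log units; within the scatter), concerns a different change and stayed within the scatter, so it offers little guidance, and no step swapping a fluoromethyl for a chloro has been measured here. The free fraction of compound 4 is therefore expected to sit close to that of compound 2, with an estimated step of a 1.1-fold lower number from compound 2 to compound 4 (0.02 log units; within the scatter). Compound 4 is expected to give 0.04, in the range 0.02 to 0.08.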

Compound 4, unbound fraction: 0.022
Estimate against measurement, compound 4: 1.8-fold (0.26 log units) above; low and high end bracket the measured number.
By their numbers in this assay, from the lowest: compounds 4, 2 and 1 (each within the scatter of the next, the first and the last beyond it). At a limit, below all of these: compound 3.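

In this assay, chloro in place of fluoromethyl on this aromatic carbon, next to the ring nitrogen, gives a 1.9-fold lower number from compound 2 to compound 4 (0.28 log units; within the scatter), so this swap alone cannot be told apart from repeat-to-repeat variation. Chloro in place of methyl on the same carbon gives a 2.2-fold lower number from compound 1 to compound 4 (0.34 log units; beyond the scatter), the first step at this position to clear the scatter, though only modestly. Nothing shown here accounts for this shift. On these data alone, how an amine or a carboxylic acid on this carbon would move the free fraction remains open, as does the effect of a longer chain.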